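Replacing 5-methylthiophen-2-yl with 2-cyclopropylethynyl

The compounds below may be only part of what the source reports. "The series", "measured", "known", "first", "only" and "open" are said of these compounds alone.

In an ADME assay on HepG2 cells (Homo sapiens) for cytotoxicity, read by MTT assay, with a stated time of 24 h (on this read-out lower numbers stand for higher toxicity in this test and higher numbers for lower toxicity in this test), compound 1 `CC1Cn2c(nc([N+](=O)[O-])c2-c2ccccc2)O1` gives > 500000 nM as a limit. Compound 2 `Cc1ccc(-c2c([N+](=O)[O-])nc3n2CC(C)O3)s1` gives > 250000 nM as a limit too, so it stands without a number. The change to compound 3 `CC1Cn2c(nc([N+](=O)[O-])c2C#CC2CC2)O1` places 2-cyclopropylethynyl in place of 5-methylthiophen-2-yl on an aromatic carbon of the shared core: 2-cyclopropylethynyl in place of 5-methylthiophen-2-yl on an aromatic carbon is the full difference. For the measured compounds named here, one measured step bears on this change. It also exchanges the group on an aromatic carbon: a step that the two limits leave unreadable from compound 1 to compound 2 gives no readable size. With no measured size to carry over, no step beyond the scatter is expected in this assay and no direction can be stated. The estimate means a step that the limit leaves unreadable from compound 2 to compound 3 as the expected step. Compound 3 is estimated at 300000 nM with an expected range from 100000 nM to 600000 nM and will probably be reported only as a limit.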

Compound 3, half-maximal cytotoxic concentration: 14800 nM
Compound 3: middle estimate off by 20-fold (1.31 log units), on the high side; measured number below the stated range.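

In this assay, the group on this aromatic carbon of the shared core now shows an effect on the read-out: 2-cyclopropylethynyl in place of 5-methylthiophen-2-yl gives an at least 16-fold lower number from compound 2 to compound 3 (1.22 log units; beyond the scatter), and 2-cyclopropylethynyl in place of phenyl gives an at least 33-fold lower number from compound 1 to compound 3 (1.52 log units; beyond the scatter). For the compounds shown here, both aromatic ring groups left only limits, so compound 3 is the first compound here with a measured number, and higher toxicity in this test comes with the change to the non-aromatic group. The first step has no upper bound because it starts from a limit: the limit of > 250000 nM in this assay, at which 1 of the 3 values shown sits.

The second step is open-ended in the same way because it also starts from a limit: the limit of > 500000 nM in this assay, at which 1 of the 3 values shown sits. The compounds shown do not separate the triple bond from the three-membered ring, and a saturated 2-cyclopropylethyl chain or an amine on this carbon would bear on that.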